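The source may hold more compounds than are shown below. What is called first, only, known or untested is meant among the compounds shown, and "the series" means these compounds.

Compound 1 `CC/C(=C(/c1ccc(/C=C/C(=O)O)cc1)c1ccc2c(cnn2C)c1)c1ccccc1`: 300 nM
Compound 2 `CC/C(=C(/c1ccc(/C=C/C(=O)O)cc1)c1ccc2sncc2c1)c1ccccc1`: > 500 nM

In a functional assay on MCF7 cells (Homo sapiens) for antiproliferative activity, read by CellTiter-Glo, with a stated time of 5 days (a higher number here means a weaker inhibitor, a lower number a stronger inhibitor), compound 1 gives 300 nM. Compound 2 returns only a limit, > 500 nM, and not a number. Compound 2 therefore stands at the limit of > 500 nM in this assay, at which 1 of the 2 values shown sits.

The next compound is compound 3 `CC/C(=C(/c1ccc(/C=C/C(=O)O)cc1)c1ccc2ccccc2c1)c1ccccc1`. It keeps the shared core and changes one group: a group of 10 heavy atoms (10 carbon; 2 six-membered aromatic rings of carbon only) in place of a group of 9 heavy atoms (7 carbon, 1 nitrogen, 1 sulfur; one five-membered aromatic ring with 2 hetero atoms, one six-membered aromatic ring of carbon only), on a double-bonded chain carbon bound to an aromatic carbon and a double-bonded chain carbon. Here naphthalen-2-yl enters on a double-bonded chain carbon bound to an aromatic carbon and a double-bonded chain carbon.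

Within the data shown here, one measured step bears on this change, made at the same place: an at least 1.6-fold higher number from compound 1 to compound 2 (0.22 log units; that floor lies within the scatter). Its floor lies within the scatter, so it gives no firm size for a swap of this group, and the starting point of compound 2 is itself only a limit. No step beyond the scatter is therefore expected in this assay, in either direction. The expected size is a number no higher from compound 2 to compound 3 (the limit leaves the size open). Compound 3 may well return only a limit too. For compound 3 the estimate is 500 nM, with an expected range of 170 nM to 1500 nM.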

Compound 3, half-maximal inhibitory concentration: 180 nM
Estimate against measurement, compound 3: 2.8-fold (0.44 log units) above, and the stated range covers the measured number.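

At this place, on a double-bonded chain carbon bound to an aromatic carbon and a double-bonded chain carbon, the compounds now show a change beyond the scatter: in this assay, naphthalen-2-yl in place of the group of 9 heavy atoms that holds nitrogen and sulfur gives an at least 2.7-fold lower number from compound 2 to compound 3 (0.44 log units; beyond the scatter). Set against 1-methyl-1H-indazol-5-yl, the same group of carbon only gives a 1.7-fold lower number from compound 1 to compound 3 (0.22 log units; within the scatter), which lies within the scatter, so a group without hetero atoms holds the level of compound 1 here. The first step remains a floor and not a full size because the reading for compound 2 is only a limit: the limit of > 500 nM in this assay, at which 1 of the 3 values shown sits.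

The compounds shown leave open how this place responds to a substituent on naphthalen-2-yl, such as an amine, a methoxy group or a fluorine atom. They also leave open how far compound 2 really lies from compound 1 and compound 3, and whether these steps hold on any other cell line.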